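A few compounds are considered here, and "the series" means these few. Any claim that something is new, unique, unknown or untested is made for them only; others in the source may bear on it.

Working notes on the series. Going by the values given here, compound 1 `CCN1CC(NC(=O)[C@@H]2CCCN(S(=O)(=O)c3ccc(S(=O)(=O)N(CC)CC)cc3)C2)C1` and compound 2 `CCN(CC)S(=O)(=O)c1ccc(S(=O)(=O)N2CCC[C@@H](C(=O)NC)C2)cc1` are the two measured members. In a functional assay on MIA PaCa-2 cells (Homo sapiens) for inhibition, read by MTT assay, with a stated time of 3 days (on this read-out lower numbers stand for stronger inhibition and higher numbers for weaker inhibition), compound 1 gives only a limit, > 10000 nM. In this assay compound 2 likewise gives only a limit, > 10000 nM. Among the compounds with values here, the single step in hand, a step that the two limits leave unreadable from compound 1 to compound 2, is unreadable because both values sit at the limit of > 10000 nM in this assay, at which 2 of the 2 values shown sit, so compound 2 stands at the limit with no number. Compound 3 `CCN(CC)S(=O)(=O)c1ccc(S(=O)(=O)N2CCC[C@@H](c3nc(C)no3)C2)cc1` carries 3-methyl-1,2,4-oxadiazol-5-yl in place of methylcarbamoyl on a saturated ring carbon. Within the data shown here, no measured step bears on this change. For compound 3 the expected step is a step that the limit leaves unreadable from compound 2 to compound 3. For compound 3 in this assay the estimate is 20000 nM, expected between 5000 nM and 100000 nM.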

Compound 3, half-maximal inhibitory concentration: > 10000 nM
Compound 3 ended at the assay's limit; the forecaster's own chance of this, stated with the estimate: 80%; the middle value lies beyond the limit too.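

No step can be read among compound 1, compound 2 and compound 3, because all three stand at a limit and not at a number: the limit of > 10000 nM in this assay, at which 3 of the 3 values shown sit.

The compounds shown leave open whether any group on that saturated ring carbon gives a measurable value in this assay.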